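Methyl in Place of Hydrogen on an Aromatic Nitrogen

The source may hold more compounds than are shown below. What is called first, only, known or untested is meant among the compounds shown, and "the series" means these compounds.

All values come from a functional assay on MDA-MB-231 cells (Homo sapiens) for cytotoxicity, read by MTT assay, with a stated time of 72 h; on this read-out higher numbers stand for weaker inhibition and lower numbers for stronger inhibition:

compound 1, `CN1CCN(c2ccc(NC(=N)c3cc4cn[nH]c4cn3)cc2)CC1`, gives 47500 nM
compound 2, `CN1CCN(c2ccc(NC(=N)c3cc4cnn(C)c4cn3)cc2)CC1`, gives 30200 nM
compound 3, `N=C(Nc1cccc(C(F)(F)F)c1)c1cc2cn[nH]c2cn1`, gives > 50000 nM

Compound 1 and compound 2 share one core and differ in one place: methyl in place of hydrogen on an aromatic nitrogen. On this change the read-out moved a 1.6-fold lower number from compound 1 to compound 2 (0.20 log units; within the scatter), so the two values cannot be told apart with confidence.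

Compound 3 carries a different core, with a trifluoromethyl group on the ring attached to the amidine nitrogen. For compound 3 the assay reports only a limit, (the limit of > 50000 nM in this assay, at which 1 of the 3 values shown sits), and no number. The difference between the cores of compound 1 and compound 3 is not broken down here.

Compound 4, `Cn1ncc2cc(C(=N)Nc3cccc(C(F)(F)F)c3)ncc21`, has not yet been measured. It stands to compound 3 exactly as compound 2 stands to compound 1: methyl in place of hydrogen on an aromatic nitrogen. The place of the change is described in the same words for both pairs, so this is the same change on two different cores.

Among the compounds with values here, the only measured example of this change, the step of a 1.6-fold lower number from compound 1 to compound 2 (0.20 log units; within the scatter), stayed within the usual scatter. On that basis the step from compound 3 to compound 4 is expected to be small as well, a step that the limit leaves unreadable from compound 3 to compound 4. Since compound 3 sits at the limit (the limit of > 50000 nM in this assay, at which 1 of the 3 values shown sits), compound 4 is expected to give a limit again in most repeats. The estimate for compound 4 is 55000 nM, with an expected range from 25000 nM to 120000 nM.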

Compound 4, half-maximal inhibitory concentration: > 50000 nM
Compound 4 gave a limit, no number (the forecaster's own chance of this, stated with the estimate: 70%); the middle value lies beyond the limit too.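

In this assay compound 4 gives > 50000 nM as a limit of the assay and not as a number. Within the data shown here, compound 3 also sits at a limit, so no step from compound 3 to compound 4 can be read, and both compounds count towards this tally: the limit of > 50000 nM in this assay, at which 2 of the 4 values shown sit. The compounds shown leave open whether methyl in place of hydrogen on an aromatic nitrogen changes the read-out at all on the core of compound 3.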